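A few compounds are considered here, and "the series" means these few. Any claim that something is new, unique, unknown or untested is made for them only; others in the source may bear on it.

Measured so far in this series:
- compound 1 `COC(=O)c1c(F)cccc1-c1ccc(CCc2ncc(CC(C)(C)C)n2CCC(=O)O)cc1` — 1 nM
- compound 2 `COC(=O)c1c(F)cccc1-c1ccc(CCc2ncc(CC(C)(C)C)n2CCO)cc1` — 21 nM
- compound 3 `COC(=O)c1c(F)cccc1-c1ccc(CCc2ncc(CC(C)(C)C)n2CCNS(C)(=O)=O)cc1` — 11 nM

In an assay on cells for agonist activity at Bombesin receptor subtype-3 (Homo sapiens), read by HTRF and inositol phosphate accumulation, with a stated time of 1 h (on this read-out higher numbers stand for an effect only at larger amounts of compound and lower numbers for an effect already at smaller amounts), compound 1 stands lowest of the three. The nearest is compound 3, reached by an 11-fold higher number from compound 1 to compound 3 (1.04 log units; beyond the scatter); the furthest is compound 2, reached by a 21-fold higher number from compound 1 to compound 2 (1.32 log units; beyond the scatter). Between the two replacements of the chain carboxy the difference is a 1.9-fold lower number from compound 2 to compound 3 (0.28 log units; within the scatter), which is within the scatter, so compound 2 and compound 3 are not told apart.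

Compound 4 `CC(C)(C)Cc1cnc(CCc2ccc(-c3cccc(F)c3C(=O)O)cc2)n1CCC(=O)O` is the next structure, not yet measured. It differs from compound 1 by hydrogen in place of methyl on an oxygen next to a carbonyl group. Among the compounds with values here, every measured step changes the carboxy on the saturated chain carbon two bonds from the aromatic nitrogen, and all three measured compounds keep the methoxycarbonyl on the ring unchanged; no measured step bears on the change made in compound 4. Compound 4 keeps the chain carboxy that separates compound 1 from compound 2 and compound 3, so the comparison starts from the lowest number. Within the data shown here, with no measured precedent for the ring-side change, the expected step for compound 4 is a 4.0-fold higher number from compound 1 to compound 4 (0.60 log units; beyond the scatter), with a wide range in either direction. Compound 4 is estimated at 4 nM, between 0.8 nM and 30 nM.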

Compound 4, half-maximal effective concentration: 11 nM
The estimate for compound 4 lay 2.8-fold (0.44 log units) below the measured number; the measured number falls inside the stated range.
By their numbers in this assay, from the lowest: compound 1; then compounds 3, 4 and 2 (each within the scatter of the next).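

In this assay, within the data shown here, the change from methoxycarbonyl to carboxy gives an 11-fold higher number from compound 1 to compound 4 (1.04 log units; beyond the scatter) and is the first measured change at this group, as every earlier step altered the chain carboxy instead. Compound 4 keeps that chain carboxy, so the chain carboxy alone does not hold the number at the level of compound 1, and the methyl on an oxygen next to a carbonyl group also matters in this series. Nothing on hand accounts for the size of this step.

Open, on these data alone, is whether the same change gives a step of similar size when the chain carries hydroxy or methanesulfonamido in place of carboxy, as the methoxycarbonyl to carboxy change is read only with the chain carboxy in place. Also open, as far as these compounds go, is how an ethyl or a longer chain in place of the methyl on this oxygen, or a primary amide in place of the methoxycarbonyl, would stand against compound 1.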